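This account rests on a few compounds, and the source may have more. Where it says the series, first, only, none or still open, it means among the compounds named here.

Compound 2, `Nc1scc(CN2CCN(c3ccc([N+](=O)[O-])cc3)CC2)c1C(=O)c1ccc(Cl)cc1`, gives 1% in an assay on CHO cells for displacement of a labelled ligand from adenosine receptor A1 (Homo sapiens), read by scintillation counting, with a stated time of 120 min, tested at 10 uM; a lower number here means less inhibition, a higher number more inhibition at the concentration tested (going by the name of the read-out). It is the highest of the three numbers measured, yet it lies within the scatter of compound 1, `Nc1scc(CN2CCN(c3ccc(Cl)cc3Cl)CC2)c1C(=O)c1ccc(Cl)cc1`, with 0%, and of compound 3, `Nc1scc(CN2CCN(c3ccc(Cl)c(C(F)(F)F)c3)CC2)c1C(=O)c1ccc(Cl)cc1`, with 0%. Compound 4, `Nc1scc(CN2CCN(c3cccc(F)c3)CC2)c1C(=O)c1ccc(Cl)cc1`, differs from compound 2 by 3-fluorophenyl in place of 4-nitrophenyl on an amine nitrogen in a ring. Within the data shown here, three steps bear on this, each a swap of the aryl group on the ring nitrogen: a number 1 percentage points higher from compound 1 to compound 2 (within the scatter), a number 1 percentage points lower from compound 2 to compound 3 (within the scatter) and no change at the digits printed from compound 1 to compound 3 (within the scatter), none beyond the scatter. Compound 2 is therefore expected to change by no change at the digits printed from compound 2 to compound 4 (within the scatter) in this assay. Compound 4 is estimated at 1%, within the range 0% to 10%.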

Compound 4, a percentage reported as inhibition, at one concentration (the size of the read-out at that concentration, not a potency): 1%
Compound 4: the middle estimate sits on the measured number at the digits printed; low and high end bracket the measured number.
By their numbers in this assay, from the lowest: compounds 1, 3, 2 and 4 (each within the scatter of the next).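

In this assay, the 3-fluorophenyl group on the amine nitrogen in the ring gives no separation from any of the other aryl groups (no change at the digits printed from compound 2 to compound 4 (within the scatter); a number 1 percentage points higher from compound 3 to compound 4 (within the scatter); a number 1 percentage points higher from compound 1 to compound 4 (within the scatter)). The result extends the flat picture to an aryl group that has neither chlorine nor the hydrogen-bond acceptors of 4-nitrophenyl. No measurement offered here accounts for this flatness. On these data alone, what stays open is whether a non-aryl group on this nitrogen, such as a benzyl group or an alkyl chain, would give a different number. As far as these compounds go, a change elsewhere on the shared core also remains untested by these compounds.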